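The compounds below may be only part of what the source reports. "The series", "measured", "known", "first", "only" and "open" are said of these compounds alone.

Working notes on the series in an assay on CHO cells for inhibition of Glucagon receptor (Homo sapiens); on this read-out higher numbers stand for weaker inhibition and lower numbers for stronger inhibition.

Compound 1 `CCCCCc1c(C(C)C)nc(C(C)C)c(CO)c1-c1ccccc1N` gives 2300 nM in this assay. Compound 2 `CCCCCc1c(C(C)C)nc(C(C)C)c(CO)c1-c1ccc(F)cc1F` gives 11000 nM, and compound 3 `CCCCCc1c(C(C)C)nc(C(C)C)c(CO)c1-c1cccc(O)c1` gives 6000 nM. Of the three numbers, compound 3 holds the second highest: its nearest neighbour is compound 2, and the two are within the scatter of each other (a 1.8-fold lower number from compound 2 to compound 3 (0.26 log units; within the scatter)), while its furthest is compound 1 (a 2.6-fold higher number from compound 1 to compound 3 (0.42 log units; beyond the scatter)). The remaining step, a 4.8-fold higher number from compound 1 to compound 2 (0.68 log units; beyond the scatter), is the largest in the set, though still modest.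

Compound 4 `CCCCCc1c(C(C)C)nc(C(C)C)c(CO)c1-c1ccc(F)c(F)c1` has not yet been measured. The change from compound 3 is 3,4-difluorophenyl in place of 3-hydroxyphenyl on an aromatic carbon. For the measured compounds named here, only one measured step bears on it directly: the exchange of a fluorinated phenyl for the 3-hydroxyphenyl, a 1.8-fold lower number from compound 2 to compound 3 (0.26 log units; within the scatter), which did not leave the scatter. Going by the values given here, the step from compound 3 to compound 4 runs in the opposite direction of that exchange, and no measured pair isolates the 3,4-difluorophenyl itself. The step in this assay is therefore expected to be small, if anything a slightly higher number: a 1.5-fold higher number from compound 3 to compound 4 (0.18 log units; within the scatter) is the expected change. For compound 4 the estimate in this assay is 9000 nM, expected to fall between 4000 nM and 20000 nM.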

Compound 4, half-maximal inhibitory concentration: 1100 nM
For compound 4 the middle estimate is 8.2-fold (0.91 log units) above the measured one, outside the stated range (below it).
By their numbers in this assay, from the lowest: compound 4; then compound 1; then compounds 3 and 2 (each within the scatter of the next).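

At the aromatic carbon opposite the ring nitrogen, the placement of the fluorines matters in this assay: 3,4-difluorophenyl in place of 2,4-difluorophenyl gives a 10-fold lower number from compound 2 to compound 4 (1.00 log units; beyond the scatter), the largest step in the set, so the presence of two fluorines does not by itself fix the number. The hydroxyl of the 3-hydroxyphenyl is also not required for the lower numbers, as the 3,4-difluorophenyl, with 0 hydrogen-bond donors, gives a 5.5-fold lower number from compound 3 to compound 4 (0.74 log units; beyond the scatter), and it also moves past the earlier lowest number, that of the 2-aminophenyl, with a 2.1-fold lower number from compound 1 to compound 4 (0.32 log units; beyond the scatter), which makes compound 4 the strongest of the four. No measurement shown here bears on why the arrangement of the fluorines counts for this much.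

Whether a single fluorine carries the gain remains open, since neither 3-fluorophenyl nor 4-fluorophenyl appears among these compounds, and 3,4-dichlorophenyl would test whether the pattern extends beyond fluorine. From the compounds shown here alone, the hydroxymethyl and pentyl groups stay fixed throughout, so a carboxylic acid at the former or a longer chain at the latter remains untested alongside the 3,4-difluorophenyl.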